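Naphthalen-1-yl in Place of 3,5-Dichlorophenyl on a Ring Nitrogen

The compounds below may be only part of what the source reports. "The series", "measured", "known", "first", "only" and "open" are said of these compounds alone.

Compound 1 `Nc1scc(CN2CCN(c3cc(Cl)cc(Cl)c3)CC2)c1C(=O)c1ccc(Cl)cc1`: 1%
Compound 2 `Nc1scc(CN2CCN(c3ccccc3C(F)(F)F)CC2)c1C(=O)c1ccc(Cl)cc1`: 0%

In an assay on CHO cells for displacement of a labelled ligand from adenosine receptor A1 (Homo sapiens), read by scintillation counting, with a stated time of 120 min, tested at 10 uM (a lower number here means less inhibition, a higher number more inhibition at the concentration tested (going by the name of the read-out)), compound 1 gives 1%, and compound 2 gives 0%; the two numbers sit within the scatter of each other. Compound 3 `Nc1scc(CN2CCN(c3cccc4ccccc34)CC2)c1C(=O)c1ccc(Cl)cc1` differs from compound 1 in the group on the ring nitrogen: naphthalen-1-yl in place of 3,5-dichlorophenyl on an amine nitrogen in a ring. Among the compounds with values here, the only measured step touching that nitrogen, a number 1 percentage points lower from compound 1 to compound 2 (within the scatter), moved nothing beyond the scatter. Compound 3 is therefore expected to show no step beyond the scatter, a number 1 percentage points higher from compound 1 to compound 3 (within the scatter). The estimate for compound 3 in this assay is 2%, within a range from 0% to 12%.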

Compound 3, a percentage reported as inhibition, at one concentration (the size of the read-out at that concentration, not a potency): 1%
The estimate for compound 3 lay 1 percentage points above the measured number, within the range that was stated.
By their numbers in this assay, from the lowest: compounds 2, 1 and 3 (each within the scatter of the next).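

In this assay naphthalen-1-yl in place of 3,5-dichlorophenyl brought no change at the digits printed from compound 1 to compound 3 (within the scatter) and in place of 2-(trifluoromethyl)phenyl it brought a number 1 percentage points higher from compound 2 to compound 3 (within the scatter). Going from one six-membered aromatic ring to two on this ring nitrogen therefore left the reading within the scatter, so all three groups shown here read alike at this position. No evidence is available that bears on this result. Still open, as far as these compounds go, is whether a carboxylic acid, a primary amine or a pyridine ring on this nitrogen would move the reading beyond the scatter.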